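A few compounds are considered here, and "the series" means these few. Any claim that something is new, unique, unknown or untested is made for them only; others in the source may bear on it.

Compound 1 `Cc1noc(CC2OC(=O)c3ccccc32)n1`: in an ADME assay on RAW264.7 cells (Mus musculus) for cytotoxicity, read by MTT assay, with a stated time of 24 h, in the presence of a further agent that is not named here (a higher number here means a weaker inhibitor, a lower number a stronger inhibitor), compound 1 gives > 40000 nM, a limit of the assay.
Compound 2 `O=C1OC(Cc2nc(-c3ccc(Oc4ccccc4)cc3)no2)c2ccccc21`: compound 2 gives > 40000 nM, again a limit.
Compound 3 `CCC(C)Oc1ccc(C(O)C2OC(=O)c3c(OC)cc(OC)cc32)cc1`: compound 3 gives > 40000 nM, also a limit.

Compound 3 therefore does not stand at a number at all; its result is only a limit of this assay, and the other two measured compounds share the same limit, so nothing separates the three of them. This is the whole picture: the limit of > 40000 nM in this assay, at which 3 of the 3 values shown sit.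

Compound 4 `COc1cc(OC)c2c(c1)C(C(O)c1ccc(OCc3ccc(Cl)cc3)cc1)OC2=O` has not yet been measured. It differs from compound 3 in one place: 4-chlorobenzyl in place of sec-butyl on an oxygen on an aromatic ring. For the measured compounds named here, no measured pair shows what such a change does here, so the expectation rests only on where compound 3 sits. Since every result so far is a limit, compound 4 is expected to sit at the same limit, and the step from compound 3 to compound 4 is expected to be none beyond the scatter, a number no higher from compound 3 to compound 4 (the limit leaves the size open). Compound 4 is estimated at 40000 nM, between 20000 nM and 80000 nM.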

Compound 4, half-maximal inhibitory concentration: > 40000 nM
Compound 4: no number, only a limit (the forecaster's own chance of this, stated with the estimate: 80%); the middle value lies on the limit itself.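

Compound 3 and compound 4 each give only a limit in this assay, so no step can be read between them. The compounds shown leave open how far each lies from that limit, and whether any change to the shared core would give a measurable number.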